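Pyridinyl to fluorophenyl on the aminobenzamide series

This account rests on a few compounds, and the source may have more. Where it says the series, first, only, none or still open, it means among the compounds named here.

Compound 3 `CCN(Cc1ccccn1)c1ccc(C(=O)N2CCc3ccc(OS(N)(=O)=O)cc3C2)cc1` stands in a physicochemical assay for lipophilicity (on this read-out higher numbers stand for higher lipophilicity and lower numbers for lower lipophilicity), at 1.93. Compound 1 `CN(C)CCN(CCN(C)C)c1ccc(C(=O)N2CCc3ccc(OS(N)(=O)=O)cc3C2)cc1` gives 1.93, and compound 2 `CCN(Cc1cccnc1)c1ccc(C(=O)N2CCc3ccc(OS(N)(=O)=O)cc3C2)cc1` gives 1.93, so compound 3 is level with both at the digits shown. The steps of no change at the digits printed from compound 1 to compound 2 (within the scatter) and no change at the digits printed from compound 1 to compound 3 (within the scatter) replace the bis(2-(dimethylamino)ethyl)amino group by ethyl((pyridin-3-yl)methyl)amino or ethyl((pyridin-2-yl)methyl)amino without moving the read-out, and the step of no change at the digits printed from compound 2 to compound 3 (within the scatter) moves the ring nitrogen of the pyridinyl without effect.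

Compound 4 `CCN(Cc1ccc(F)cc1)c1ccc(C(=O)N2CCc3ccc(OS(N)(=O)=O)cc3C2)cc1` differs from compound 3 by 4-fluorophenyl in place of pyridin-2-yl on a saturated chain carbon bound to a nitrogen on an aromatic ring. Among the compounds with values here, none of the three measured steps removes a ring nitrogen or introduces fluorine; the only step touching this ring, from compound 2 to compound 3, swaps one pyridinyl for another and is flat. A step clearly beyond the scatter towards higher lipophilicity is therefore expected on grounds of the counted loss of one hydrogen-bond acceptor, not of any measured precedent. The step from compound 3 to compound 4 is estimated at a number 1.27 log units higher from compound 3 to compound 4 (beyond the scatter). Compound 4 is expected to give 3.2, within 2.5 to 3.9.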

Compound 4, partition coefficient: 1.93
Beside the measured number, compound 4's estimate is 1.27 log units above it; the whole stated range lies above it.
By their numbers in this assay, from the lowest: compounds 1, 2, 3 and 4 (each within the scatter of the next).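

In this assay, 4-fluorophenyl in place of pyridin-2-yl on a saturated chain carbon bound to a nitrogen on an aromatic ring gives no change at the digits printed from compound 3 to compound 4 (within the scatter), and 4-fluorophenyl in place of pyridin-3-yl gives no change at the digits printed from compound 2 to compound 4 (within the scatter), so at this position the flat result now extends beyond moving the ring nitrogen to a ring of carbon only, carrying fluorine and without the hydrogen-bond acceptor counted on either pyridinyl. Ethyl(4-fluorobenzyl)amino in place of bis(2-(dimethylamino)ethyl)amino on an aromatic carbon likewise gives no change at the digits printed from compound 1 to compound 4 (within the scatter). No supporting data are available to account for this result.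

Open, from the compounds shown here alone, is whether a carboxylic acid in place of 4-fluorophenyl would separate from these four compounds in this assay. Also open, going by these compounds, is whether a longer chain in place of the ethyl in ethyl(4-fluorobenzyl)amino would do so.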